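Halogenated aryl on the hydrazone carbon of the series

The source may hold more compounds than are shown below. What is called first, only, known or untested is meant among the compounds shown, and "the series" means these compounds.

Measured so far:
compound 1 `COc1ccc(/C=N/NC(=O)Nc2ccc(Oc3ccnc(-c4nncn4CCN(C)C)c3)c(F)c2)c(OC)c1OC` — 2020 nM
compound 2 `CN(C)CCn1cnnc1-c1cc(Oc2ccc(NC(=O)N/N=C/c3ccccc3)cc2F)ccn1` — 2730 nM

In a functional assay on MKN-45 cells (Homo sapiens) for cytotoxicity, read by MTT assay, with a stated time of 72 h (on this read-out higher numbers stand for weaker inhibition and lower numbers for stronger inhibition), compound 2 gives 2730 nM. Compound 1 gives 2020 nM, and the two numbers lie within the scatter of each other. Within the data shown here, the only measured step at the carbon with a double bond to nitrogen is a 1.4-fold higher number from compound 1 to compound 2 (0.13 log units; within the scatter). Compound 3 `CN(C)CCn1cnnc1-c1cc(Oc2ccc(NC(=O)N/N=C/c3ccc(F)cc3Cl)cc2F)ccn1` differs from compound 2 by 2-chloro-4-fluorophenyl in place of phenyl on a carbon with a double bond to nitrogen. Among the measured compounds shown here, no measured step covers chlorine or fluorine on that ring. For the measured compounds named here, the one step there, a 1.4-fold higher number from compound 1 to compound 2 (0.13 log units; within the scatter), stayed within the scatter, so the expected step in this assay is a 1.1-fold lower number from compound 2 to compound 3 (0.04 log units; within the scatter), not beyond the scatter. Compound 3 is estimated at 2500 nM, ranging from 1000 nM to 7000 nM.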

Compound 3, half-maximal inhibitory concentration: 870 nM
Compound 3: the middle estimate sits 2.9-fold (0.46 log units) above what was measured; the measured number lies below the stated range.
By their numbers in this assay, from the lowest: compound 3; then compounds 1 and 2 (each within the scatter of the next).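

Among these compounds, at the carbon with a double bond to nitrogen, 2-chloro-4-fluorophenyl in place of phenyl gives a 3.1-fold lower number from compound 2 to compound 3 (0.50 log units; beyond the scatter) in this assay, the first step at this position beyond the scatter. In place of 2,3,4-trimethoxyphenyl, the same group gives a 2.3-fold lower number from compound 1 to compound 3 (0.37 log units; beyond the scatter) as well, so the position does respond to a change of aryl group, though both steps are modest. The compounds shown leave open how the step divides between the chlorine and the fluorine, and how an amine or a carboxylic acid on that ring would read. Nothing measured here accounts for this change.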